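This account rests on a few compounds, and the source may have more. Where it says the series, first, only, none or still open, it means among the compounds named here.

Of the compounds shown here, three have been measured in an ADME assay on isolated protein for inhibition of Amine oxidase [flavin-containing] B (Homo sapiens); on this read-out lower numbers stand for stronger inhibition and higher numbers for weaker inhibition. Compound 1, `C#CCNC1CCc2c(SCCc3cccc(Br)c3)cccc21`, gives 620 nM, the lowest of the three numbers. Compound 2, `C#CCNC1CCc2c(SCc3cccc(OC)c3)cccc21`, gives 1520 nM, a higher number than that of compound 1 by more than the usual scatter of repeated measurements. Compound 3, `C#CCNC1CCc2c(NCc3cccc(C(F)(F)F)c3)cccc21`, gives 11300 nM, much higher still and far beyond the scatter. Compound 1 therefore stands as the strongest inhibitor of the three, and every other measured compound is clearly weaker.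

The next compound, compound 4, `C#CCNC1CCc2c(SCCc3cccc(F)c3)cccc21`, has not yet been measured in this assay. It keeps the whole of compound 1 apart from one change: fluoro in place of bromo on an aromatic carbon. Going by the values given here, the fluoro group takes the spot on the aromatic carbon of the six-membered aromatic ring of carbon only that the bromo group held, and nothing else in the structure moves.

Among the compounds with values here, no pair among the measured compounds shows this exact exchange, so there is no directly comparable step to lean on. The expectation is that compound 4 loses some potency, with a step from compound 1 of a 2.1-fold higher number from compound 1 to compound 4 (0.32 log units; beyond the scatter), somewhat beyond the scatter in the direction of weaker inhibition. On that basis compound 4 is estimated to give 1300 nM in this assay, expected to fall between 450 nM and 3800 nM.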

Compound 4, half-maximal inhibitory concentration: 7810 nM
Beside the measured number, compound 4's estimate is 6.0-fold (0.78 log units) below it; measured number above the stated range.
By their numbers in this assay, from the lowest: compound 1; then compound 2; then compounds 4 and 3 (each within the scatter of the next).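

In this assay, the exchange of 3-bromophenyl to 3-fluorophenyl gives a 13-fold higher number from compound 1 to compound 4 (1.10 log units; beyond the scatter), so the group at this place on the aromatic ring matters greatly, even though one heavy atom simply replaces another and the counts of rings, hydrogen-bond donors and acceptors and the net charge all stay the same. Going by these compounds alone, the earlier compounds could not show this, as each differs from the others in more than one place, so none of their gaps can be assigned to a single group; this pair is the first to isolate one change. The data shown offer no measurement that explains the size of this step.

From the compounds shown here alone, with only bromo and fluoro compared here, it remains open whether bromo is especially favourable at this place or fluoro especially poor, and a chloro, iodo or methyl group at the same spot would help separate those two readings. Going by these compounds, it is also open whether the same exchange would give a step of similar size on a compound with a different link to the shared core.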